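This account rests on a few compounds, and the source may have more. Where it says the series, first, only, none or still open, it means among the compounds named here.

In a functional assay on HT-29 cells (Homo sapiens) for inhibition, read by MTT assay, with a stated time of 48 h (on this read-out lower numbers stand for stronger inhibition and higher numbers for weaker inhibition), compound 1 `COc1cc(-c2cc(-c3ccc(Br)cc3)nc(-c3ccccc3)n2)cc(OC)c1OC` gives 3170 nM and compound 3 `COc1cc(-c2cc(-c3ccc(O)cc3O)nc(-c3ccccc3)n2)cc(OC)c1OC` gives 4960 nM. The separation between these two is a 1.6-fold higher number from compound 1 to compound 3 (0.19 log units; within the scatter), so the 4-bromophenyl and 2,4-dihydroxyphenyl groups cannot be told apart here.

Compound 2 `COc1ccc(-c2cc(-c3cc(OC)c(OC)c(OC)c3)nc(-c3ccccc3)n2)c(OC)c1` reads > 25000 nM, which is a limit of the assay and not a number. As far as these compounds go, it therefore sits at the limit of > 25000 nM in this assay, at which 1 of the 3 values shown sits, and its exact place on the scale is unknown.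

Compound 4 `COc1cc(-c2cc(-c3cccs3)nc(-c3ccccc3)n2)cc(OC)c1OC` replaces the 2,4-dimethoxyphenyl group of compound 2 with thiophen-2-yl: thiophen-2-yl in place of 2,4-dimethoxyphenyl on an aromatic carbon.

Among the compounds with values here, three measured steps bear on this change, all at the same position. The two that involve compound 2 are an at least 7.8-fold higher number from compound 1 to compound 2 (0.89 log units; beyond the scatter) and an at least 5.0-fold lower number from compound 2 to compound 3 (0.70 log units; beyond the scatter), and both are bounds only. The third is the small step between compound 1 and compound 3 noted above. Within the data shown here, no thiophen-2-yl compound has been measured, so the new group has no direct precedent.

Of the three groups tested, only the 2,4-dimethoxyphenyl of compound 2 reaches the limit. A modest or larger drop in the number is therefore expected on leaving this group, towards the level of compound 1 at 3170 nM. The expected change is an at least 4.1-fold lower number from compound 2 to compound 4 (0.61 log units; beyond the scatter). For compound 4 the estimated value is 6000 nM, with an expected range from 1800 nM to 20000 nM.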

Compound 4, half-maximal inhibitory concentration: > 25000 nM
Compound 4 gave a limit, no number; the forecaster's own chance of this, stated with the estimate: 15%; at least 4.1-fold (0.61 log units) between middle value and limit.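

In this assay compound 4 reads as a limit and not a number, so the limit at this aromatic carbon no longer belongs to the 2,4-dimethoxyphenyl group of compound 2 alone: the limit of > 25000 nM in this assay, at which 2 of the 4 values shown sit.

Replacing the two readable groups with thiophen-2-yl gives an at least 7.8-fold higher number from compound 1 to compound 4 (0.89 log units; beyond the scatter) and an at least 5.0-fold higher number from compound 3 to compound 4 (0.70 log units; beyond the scatter), so leaving 2,4-dimethoxyphenyl does not by itself bring the read-out back to the level of compound 1 and compound 3. The step between compound 2 and compound 4 cannot be read, with limits at both ends, and the two groups that share the limit differ in ring type and in heavy-atom count, so neither feature alone sorts this small set.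

The compounds shown leave open whether the readable level depends on a six-membered aromatic ring of carbon only or on the particular groups that ring carries in compound 1 and compound 3. As far as these compounds go, an unsubstituted phenyl, a 4-chlorophenyl, a 4-hydroxyphenyl or a furan-2-yl group at this carbon would help separate these possibilities, and how far compound 2 and compound 4 actually lie from each other remains unknown.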